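Swapping Two Groups on a Shared Core

This account rests on a few compounds, and the source may have more. Where it says the series, first, only, none or still open, it means among the compounds named here.

Measured so far:
compound 1, `CC1=NC(C)=C(C(=O)OCCCN2C(=O)c3ccccc3S2(=O)=O)C(c2ccccc2[N+](=O)[O-])/C1=C(\O)OC(C)C`, gives 1.2 nM in a functional assay (aorta) with Oryctolagus cuniculus as the target; a higher number here means a weaker inhibitor, a lower number a stronger inhibitor;
compound 2, `COCCO/C(O)=C1\C(C)=NC(C)=C(C(=O)OCCCN2C(=O)c3ccccc3S2(=O)=O)C1c1ccccc1[N+](=O)[O-]`, gives 2.7 nM;
compound 3, `CC1=NC(C)=C(C(=O)OCCCN2C(=O)c3ccccc3S2(=O)=O)C(c2ccccc2C(F)(F)F)/C1=C(\O)OC(C)C`, gives 2.7 nM.

Compound 2 differs from compound 1 in one place, (2-methoxyethyl in place of isopropyl on an oxygen on an unsaturated carbon), and that change gave a 2.3-fold higher number from compound 1 to compound 2 (0.35 log units; beyond the scatter). Compound 3 differs from compound 1 by trifluoromethyl in place of nitro on an aromatic carbon, which gave a 2.3-fold higher number from compound 1 to compound 3 (0.35 log units; beyond the scatter). Compound 2 and compound 3 stand level at the digits shown.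

Compound 4, `COCCO/C(O)=C1\C(C)=NC(C)=C(C(=O)OCCCN2C(=O)c3ccccc3S2(=O)=O)C1c1ccccc1C(F)(F)F`, is not yet measured. It differs from compound 3 by 2-methoxyethyl in place of isopropyl on an oxygen on an unsaturated carbon, the same change already seen between compound 1 and compound 2, now made on the core of compound 3. Because that earlier step was a 2.3-fold higher number from compound 1 to compound 2 (0.35 log units; beyond the scatter), a modest step of similar size is expected here; for compound 4 the expected step is a 2.2-fold higher number from compound 3 to compound 4 (0.35 log units; beyond the scatter). Compound 4 is therefore estimated to give 6 nM in this assay, most likely between 3 nM and 13 nM.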

Compound 4, half-maximal inhibitory concentration: 1.4 nM
The estimate for compound 4 lay 4.3-fold (0.63 log units) above the measured number; measured number below the stated range.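

Made on the core of compound 3, the change to 2-methoxyethyl gives a 1.9-fold lower number from compound 3 to compound 4 (0.29 log units; within the scatter) in this assay, so it does not repeat the earlier step, as this comparison shows: the same change on two cores in this assay, a 2.3-fold higher number (0.35 log units; beyond the scatter) from compound 1 to compound 2 and a 1.9-fold lower number (0.29 log units; within the scatter) from compound 3 to compound 4, 4.3-fold (0.64 log units) apart, beyond the scatter of two such steps. The change to trifluoromethyl behaves alike, giving a 1.9-fold lower number from compound 2 to compound 4 (0.29 log units; within the scatter) on the core of compound 2, which again differs from its earlier step: the same change on two cores in this assay, a 2.3-fold higher number (0.35 log units; beyond the scatter) from compound 1 to compound 3 and a 1.9-fold lower number (0.29 log units; within the scatter) from compound 2 to compound 4, 4.3-fold (0.64 log units) apart, beyond the scatter of two such steps. Neither change can therefore be carried from one core to the other as a fixed step, but these four compounds do not show why the steps differ.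

The compounds shown leave open how a longer ether chain in place of isopropyl would behave on these two cores. They also leave open how a nitrile in place of nitro would behave.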